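Swapping the amine-bearing ring on a cyclopropane core

The source may report more compounds than this note shows. Statements on the series, on what has been measured and on what is new or still open speak of the compounds shown alone.

Of the compounds shown here, two built on the same three-membered carbon ring have been measured in a functional assay on AP1 cells for inhibition of sodium/hydrogen exchanger 1 (Homo sapiens); on this read-out higher numbers stand for weaker inhibition and lower numbers for stronger inhibition. Compound 1 `Cc1[nH]cnc1[C@@H]1[C@@H](c2cc(Cl)cc(Cl)c2)C1(C)C` gives 950 nM in this assay. Going by the values given here, compound 2 `CC1(C)[C@H](c2cc(Cl)cc(Cl)c2)[C@H]1c1c[nH]c(N)n1` gives 180 nM in this assay, which is the lower of the two numbers; the only measured step leading to it is a 5.3-fold lower number from compound 1 to compound 2 (0.72 log units; beyond the scatter), so compound 2 stands as the stronger inhibitor of the pair.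

Compound 3 `CC1(C)[C@H](c2cc(Cl)cc(Cl)c2)[C@H]1c1cnc(N)s1` has not yet been measured. It differs from compound 2 in one place: 2-amino-1,3-thiazol-5-yl in place of 2-amino-1H-imidazol-4-yl on a saturated ring carbon. Among the compounds with values here, the single measured step, from compound 1 to compound 2, also replaced the five-membered aromatic ring on that saturated ring carbon, and was modest in size. Within the data shown here, no step with a sulfur-containing ring has been measured, so the direction of the change cannot be read directly from the data. The amino group on the ring is kept while a ring nitrogen and a hydrogen-bond donor are lost, and a moderate weakening is expected for compound 3, namely a 3.3-fold higher number from compound 2 to compound 3 (0.52 log units; beyond the scatter). The estimate for compound 3 in this assay is therefore 600 nM, with a range from 150 nM to 2500 nM.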

Compound 3, half-maximal inhibitory concentration: > 30000 nM
Compound 3: no number, only a limit (the forecaster's own chance of this, stated with the estimate: 10%); at least 50-fold (1.69 log units) between middle value and limit.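

In this assay compound 3 gives no number, only a limit of the assay: the limit of > 30000 nM in this assay, at which 1 of the 3 values shown sits.

Keeping the amino group is therefore not enough to keep the inhibition, as 2-amino-1,3-thiazol-5-yl in place of 2-amino-1H-imidazol-4-yl gives an at least 160-fold higher number from compound 2 to compound 3 (2.22 log units; beyond the scatter) and this large step contrasts with the modest earlier change on the same saturated ring carbon. The thiazole also falls well behind the 5-methyl-1H-imidazol-4-yl group, which has no amino group, with an at least 31-fold higher number from compound 1 to compound 3 (1.49 log units; beyond the scatter) as the step between those two compounds. Among these three compounds, then, the identity of the five-membered ring matters more at this position than the presence of the amino group, and both compounds with an imidazole ring give measurable numbers.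

The single swap changes the ring atoms, the hydrogen-bond donor and acceptor counts and the attachment point together, so the compounds shown cannot say which of these matters or why inhibition is lost. On these data alone, a 2-amino-1,3-thiazol-4-yl or a 2-amino-1,3-oxazol-5-yl group on the same carbon could begin to separate these changes, and how either would behave remains open.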